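A Second Methoxy Group on Compound 3

This account rests on a few compounds, and the source may have more. Where it says the series, first, only, none or still open, it means among the compounds named here.

In a functional assay on MCF cells (Homo sapiens) for antiproliferative activity, with a stated time of 72 h (a lower number here means a stronger inhibitor, a higher number a weaker inhibitor), compound 1 `OC[C@H]1O[C@@H](n2cnc3c(NCc4cccc(F)c4)ncnc32)[C@H](O)[C@@H]1O` gives 15300 nM. Compound 2 `OC[C@H]1O[C@@H](n2cnc3c(NCc4cccc(Br)c4)ncnc32)[C@H](O)[C@@H]1O` is reported only as a limit, > 166000 nM. Compound 3 `COc1ccccc1CNc1ncnc2c1ncn2[C@@H]1O[C@H](CO)[C@@H](O)[C@H]1O` is also reported only as a limit, > 166000 nM. This is the limit of > 166000 nM in this assay, at which 2 of the 3 values shown sit.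

Compound 4 `COc1ccc(CNc2ncnc3c2ncn3[C@@H]2O[C@H](CO)[C@@H](O)[C@H]2O)c(OC)c1` carries methoxy in place of hydrogen on an aromatic carbon, which turns 2-methoxyphenyl into 2,4-dimethoxyphenyl.

Two measured changes on the aromatic ring bear on this, and both are large and beyond the scatter: an at least 10-fold higher number from compound 1 to compound 2 (1.03 log units; beyond the scatter), and an at least 10-fold higher number from compound 1 to compound 3 (1.03 log units; beyond the scatter). The third, a step that the two limits leave unreadable from compound 2 to compound 3, gives no size. Among the compounds with values here, no measured step adds a methoxy to a ring that already has one, so this rests on indirect evidence. Both readable steps lead away from compound 1 to the limit, and no recovery is expected from the added group. The expected outcome is a number no higher from compound 3 to compound 4 (the limit leaves the size open), with no change beyond the scatter and quite possibly another limit. For compound 4 the estimate is 166000 nM, with an expected range of 50000 nM to 400000 nM.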

Compound 4, half-maximal inhibitory concentration: > 166000 nM
Compound 4 ended at the assay's limit (the forecaster's own chance of this, stated with the estimate: 75%); the middle value sits exactly at the limit.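

The added methoxy, para to a large group and meta to a methoxy group, does not bring compound 4 off the limit in this assay, so a second methoxy on this ring gives no measurable activity. The 2,4-dimethoxyphenyl group in place of 3-fluorophenyl gives an at least 10-fold higher number from compound 1 to compound 4 (1.03 log units; beyond the scatter), making it the third group on this chain carbon to end at the limit. The steps to compound 4 from compound 2 and from compound 3 cannot be read, and the values now gather at one ceiling: the limit of > 166000 nM in this assay, at which 3 of the 4 values shown sit.

As far as these compounds go, how far the methoxy shifts activity at this position stays open, since the limit hides any difference. Also open, from the compounds shown here alone, is whether a hydroxyl or an amine at this ring carbon, or a methoxy added to the 3-fluorophenyl ring of compound 1, would give a readable number.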